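Aryl swap on the hydrazone carbon of compound 2

The source may report more compounds than this note shows. Statements on the series, on what has been measured and on what is new or still open speak of the compounds shown alone.

Among the measured compounds shown here, compound 2 `CN(C)CCn1cnnc1-c1cc(Oc2ccc(NC(=O)N/N=C/c3ccc(F)cc3Cl)cc2F)ccn1` gives 1120 nM in a functional assay on A549 cells (Homo sapiens) for cytotoxicity, read by MTT assay, with a stated time of 72 h (a higher number here means a weaker inhibitor, a lower number a stronger inhibitor), and has the highest of the three numbers measured so far, though its gaps to both other compounds lie within the scatter. Compound 1 `CN(C)CCn1cnnc1-c1cc(Oc2ccc(NC(=O)N/N=C/c3cccc(Br)c3)cc2F)ccn1` gives 970 nM in this assay, and compound 3 `CN(C)CCn1cnnc1-c1cc(Oc2ccc(NC(=O)N/N=C/c3cc(C(C)(C)C)cc(C(C)(C)C)c3O)cc2F)ccn1` gives 980 nM in this assay. For the measured compounds named here, the one step between single-change neighbours, a 1.2-fold higher number from compound 1 to compound 2 (0.06 log units; within the scatter), is within the scatter, so swapping the aryl on the carbon with a double bond to nitrogen has not yet moved the number.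

Compound 4 `CN(C)CCn1cnnc1-c1cc(Oc2ccc(NC(=O)N/N=C/c3ccc(O)cc3)cc2F)ccn1` is the next member: 4-hydroxyphenyl in place of 2-chloro-4-fluorophenyl on a carbon with a double bond to nitrogen. Going by the values given here, the step from compound 1 to compound 2 is the only measured step at the same place, and it stayed within the scatter. Compound 3, which carries a hydroxy on its aryl at the same place, gives a number within the scatter of compound 2. Nothing measured separates the aryl groups at this position, so the change to compound 4 is expected to give a step of a 1.1-fold lower number from compound 2 to compound 4 (0.05 log units; within the scatter) that stays within the scatter. Compound 4 is therefore estimated at 1000 nM in this assay, with an expected range from 400 nM to 2500 nM.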

Compound 4, half-maximal inhibitory concentration: 3560 nM
Compound 4: the middle estimate sits 3.6-fold (0.55 log units) below what was measured; the measured number lies above the stated range.
By their numbers in this assay, from the lowest: compounds 1, 3 and 2 (each within the scatter of the next); then compound 4.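

Among the compounds shown here, the aryl on the carbon with a double bond to nitrogen is not a silent position in this assay: 4-hydroxyphenyl gives a 3.2-fold higher number from compound 2 to compound 4 (0.50 log units; beyond the scatter) and a 3.7-fold higher number from compound 1 to compound 4 (0.56 log units; beyond the scatter), the first steps at this place beyond the scatter. A hydroxy on the aryl does not on its own go with the higher number, and compound 3 goes against such a reading: it carries a hydroxy together with tert-butyl groups and gives 980 nM. No measurement at hand accounts for the higher number of compound 4.

The compounds shown do not separate the loss of the halogens from the arrival of the hydroxy, a question that unsubstituted phenyl, methoxyphenyl or aminophenyl at this carbon would bear on. As far as these compounds go, it also stays open whether the same aryl swap gives a step of similar size when the dimethylaminoethyl chain of the shared core is replaced by a longer chain or a carboxylic acid.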